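A few compounds are considered here, and "the series" means these few. Any claim that something is new, unique, unknown or untested is made for them only; others in the source may bear on it.

Within the data shown here, compound 2 `COC(=O)CNC(=O)c1ccc(C(=O)NC[C@H]2COc3ccccc3O2)cc1-c1ccccc1C` is one of two compounds measured in a functional assay (HSMC cells, Homo sapiens) for antiproliferative activity, with a stated time of 72 h (on this read-out lower numbers stand for stronger inhibition and higher numbers for weaker inhibition), where compound 2 gives 113000 nM. Among the measured compounds shown here, its only companion is compound 1 `COC(=O)[C@H](CCSC)NC(=O)c1ccc(C(=O)NC[C@H]2COc3ccccc3O2)cc1-c1ccccc1C`, which in this assay gives 87000 nM; the step of a 1.3-fold higher number from compound 1 to compound 2 (0.11 log units; within the scatter) separates them, so the two numbers sit together rather than apart. Compound 3 `COC(=O)[C@H](CC(C)C)NC(=O)c1ccc(C(=O)NC[C@H]2COc3ccccc3O2)cc1-c1ccccc1C` is not yet measured. It differs from compound 2 by isobutyl in place of hydrogen on a saturated chain carbon bound to an amide-type nitrogen and a carbonyl carbon. For the measured compounds named here, the single measured step that bears on this change is a 1.3-fold higher number from compound 1 to compound 2 (0.11 log units; within the scatter), which placed a 2-(methylsulfanyl)ethyl group on the same saturated chain carbon and left the number essentially unchanged. Going by the values given here, with only that step as a guide, the isobutyl group is expected to produce no shift beyond the scatter, so the estimated step is a 1.3-fold lower number from compound 2 to compound 3 (0.10 log units; within the scatter). Compound 3 is therefore expected to give about 90000 nM in this assay, with a range from 40000 nM to 200000 nM.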

Compound 3, half-maximal inhibitory concentration: 103000 nM
Estimate against measurement, compound 3: 1.1-fold (0.06 log units) below; measured number inside the range.
By their numbers in this assay, from the lowest: compounds 1, 3 and 2 (each within the scatter of the next).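

In this assay, isobutyl in place of hydrogen on a saturated chain carbon bound to an amide-type nitrogen and a carbonyl carbon gives a 1.1-fold lower number from compound 2 to compound 3 (0.04 log units; within the scatter), so a group of carbon alone now joins 2-(methylsulfanyl)ethyl in causing no shift beyond the scatter. Isopropyl in place of (methylsulfanyl)methyl, two bonds along the chain from that nitrogen and carbonyl carbon, gives a 1.2-fold higher number from compound 1 to compound 3 (0.07 log units; within the scatter), so the sulfur-bearing chain and the isobutyl chain cannot be told apart on these numbers. Nothing available gives a reason for this lack of change. The compounds shown leave open whether an amine, a carboxylic acid or a phenyl ring on the same saturated chain carbon would move the number beyond the scatter. They also leave open whether a carboxylic acid in place of the methyl ester would do so.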